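Chloro for Hydrogen on a Benzylidene Chalcone Pair

The source may report more compounds than this note shows. Statements on the series, on what has been measured and on what is new or still open speak of the compounds shown alone.

The compounds measured so far, with their growth-inhibition numbers:
- compound 1, `O=C(/C(=C/c1ccc(Cl)cc1)CCl)c1ccccc1`, gives 22000 nM
- compound 2, `CC(=O)OC/C(=C/c1ccc(Cl)cc1)C(=O)c1ccc(Cl)cc1`, gives 5700 nM
- compound 3, `C=C(C/C(=C\c1ccccc1)C(=O)c1ccccc1)C(=O)c1ccccc1`, gives 19000 nM

All three were tested in a functional assay on HeLa cells (Homo sapiens) for inhibition, read by sulforhodamine B assay, with a stated time of 48 h; on this read-out higher numbers stand for weaker inhibition of growth and lower numbers for stronger inhibition of growth. Compound 3 stands at the second highest of the three numbers. Its nearest neighbour is compound 1, whose number lies within the scatter of that of compound 3, so the two cannot be told apart on this read-out. Compound 2 is the furthest away, with a number that is lower than that of compound 3 by more than the scatter allows; compound 2 carries a chlorine on each of its two outer rings.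

Compound 4, `C=C(C/C(=C\c1ccc(Cl)cc1)C(=O)c1ccccc1)C(=O)c1ccccc1`, differs from compound 3 in one place: chloro in place of hydrogen on an aromatic carbon. Within the data shown here, no directly comparable pair among the measured compounds isolates this change, so the expectation for compound 4 rests only on the general observation that the chlorine-bearing compound 2 gives the lowest number among the three. A small step toward a lower number is expected from compound 3 to compound 4, a 1.6-fold lower number from compound 3 to compound 4 (0.20 log units; within the scatter), one that may well stay within the scatter. Compound 4 is estimated at 12000 nM, with a range from 5000 nM to 30000 nM.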

Compound 4, concentration for 50% growth inhibition: 22000 nM
Compound 4: the middle estimate sits 1.8-fold (0.26 log units) below what was measured; measured number inside the range.
By their numbers in this assay, from the lowest: compound 2; then compounds 3, 1 and 4 (each within the scatter of the next).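

In this assay, the change from phenyl to 4-chlorophenyl gives a 1.2-fold higher number from compound 3 to compound 4 (0.06 log units; within the scatter), so chloro in place of hydrogen at this place, on an aromatic carbon para to a large group, does not separate the two compounds on this read-out. Among these compounds, this is the first pair in the set that differs in one place, and it gives the chlorine a reading of its own, which the earlier compounds could not, since they differ from one another in more than one place. No measurement available here accounts for the two numbers lying so close together.

As far as these compounds go, whether another group at this same place, such as an amine, a carboxylic acid or a methoxy group, would shift the number beyond the scatter remains open. From the compounds shown here alone, it is equally open whether chloro on either of the other aromatic rings of the core of compound 3 would behave as it does here, or whether the chlorine in compound 2 has any part in its number.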